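Series notes: fluoro step from compound 2 to compound 3

The source may report more compounds than this note shows. Statements on the series, on what has been measured and on what is new or still open speak of the compounds shown alone.

Measured so far:
compound 1 `CC(=O)C(CSC(=S)N(C)C)CSC(=S)N(C)C` gives 890 nM in a functional assay on NCI-H460 cells (Homo sapiens) for inhibition, read by MTT assay, with a stated time of 72 h; a higher number here means a weaker inhibitor, a lower number a stronger inhibitor
compound 2 `CN(C)C(=S)SCC(CSC(=S)N(C)C)C(=O)c1ccccc1` gives 1930 nM in this assay

Within the data shown here, compound 2 stands at the highest of the two numbers so far in this assay; the only step in hand, a 2.2-fold higher number from compound 1 to compound 2 (0.34 log units; beyond the scatter), is a modest one and moves the number upward. Compound 3 `CN(C)C(=S)SCC(CSC(=S)N(C)C)C(=O)c1ccc(F)cc1` differs from compound 2 by fluoro in place of hydrogen on an aromatic carbon. Among the measured compounds shown here, no measured step bears on the aromatic ring: the one step recorded concerns the group on the carbonyl carbon and offers no direct guide to a change on the ring. With nothing in the present data pointing either way, the expected step of a 1.1-fold lower number from compound 2 to compound 3 (0.03 log units; within the scatter) is none beyond the scatter. Compound 3 is therefore estimated at 1800 nM in this assay, with a range from 900 nM to 3600 nM; the measurement will settle whether the ring tolerates the substituent without cost.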

Compound 3, half-maximal inhibitory concentration: 1210 nM
Estimate against measurement, compound 3: 1.5-fold (0.17 log units) above; low and high end bracket the measured number.
By their numbers in this assay, from the lowest: compounds 1, 3 and 2 (each within the scatter of the next, the first and the last beyond it).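

Working notes: in this assay, the six-membered aromatic ring accepts fluoro on the carbon para to a large group with no step beyond the scatter (a 1.6-fold lower number from compound 2 to compound 3 (0.20 log units; within the scatter)). Exchanging methyl on the carbonyl carbon for 4-fluorophenyl also stays within the scatter (a 1.4-fold higher number from compound 1 to compound 3 (0.13 log units; within the scatter)), whereas the exchange for unsubstituted phenyl lies beyond it, so the small cost of phenyl is not clearly retained once fluoro is present. No supporting data bear on the origin of either step.

A single halogen at one ring carbon does not define the tolerance of this position, and chloro, methoxy or an amine there could behave differently. Going by these compounds, whether the other ring carbons accept fluoro, and whether a longer alkyl chain on the carbonyl carbon is accepted, remains open.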